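The source may hold more compounds than are shown below. What is called first, only, known or untested is meant among the compounds shown, and "the series" means these compounds.

Working notes on the series. All three measured members share one core; compound 1 is `O=C(Nc1ccccc1[N+](=O)[O-])c1ccc(/N=N\c2c[nH]c3ccccc23)cc1`, compound 2 is `Cc1ccc(C)c(NC(=O)c2ccc(/N=N\c3c[nH]c4ccccc34)cc2)c1` and compound 3 is `O=C(Nc1cccc(Cl)c1)c1ccc(/N=N\c2c[nH]c3ccccc23)cc1`. In a functional assay on HCT-116 cells (Homo sapiens) for inhibition, read by MTT assay, with a stated time of 72 h (a lower number here means a stronger inhibitor, a higher number a weaker inhibitor), compound 1 gives 208000 nM, which places it second highest of the three numbers; compound 2 gives 544000 nM and compound 3 gives 80000 nM. The steps among them all sit on the amide-type nitrogen: a 2.6-fold higher number from compound 1 to compound 2 (0.42 log units; beyond the scatter), a 2.6-fold lower number from compound 1 to compound 3 (0.41 log units; beyond the scatter) and a 6.8-fold lower number from compound 2 to compound 3 (0.83 log units; beyond the scatter). The unmeasured member, compound 4, is `O=C(Nc1ccc([N+](=O)[O-])cc1)c1ccc(/N=N\c2c[nH]c3ccccc23)cc1`; it differs from compound 1 as follows: 4-nitrophenyl in place of 2-nitrophenyl on an amide-type nitrogen. Going by the values given here, none of the measured steps moves a nitro group within the ring; they only show that exchanges of the whole group on this nitrogen shift this assay modestly, never strongly. On that basis a step from compound 1 to compound 4 is expected to be small, within or just beyond the scatter, with a slight lean toward a lower number, and is estimated as a 1.4-fold lower number from compound 1 to compound 4 (0.14 log units; within the scatter). Compound 4 is accordingly expected to give about 150000 nM in this assay, estimated to lie between 50000 nM and 450000 nM.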

Compound 4, half-maximal inhibitory concentration: 156000 nM
Compound 4: the middle estimate sits 1.0-fold (0.02 log units) below what was measured; low and high end bracket the measured number.
By their numbers in this assay, from the lowest: compounds 3, 4 and 1 (each within the scatter of the next, the first and the last beyond it); then compound 2.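

Exchanging 2-nitrophenyl for 4-nitrophenyl on the amide-type nitrogen gives a 1.3-fold lower number from compound 1 to compound 4 (0.12 log units; within the scatter) in this assay, so for this pair the site of the nitro group on the ring is not resolved from the scatter. The 4-nitrophenyl and 3-chlorophenyl groups are not separated either, with a 2.0-fold higher number from compound 3 to compound 4 (0.29 log units; within the scatter), whereas 4-nitrophenyl does stand apart from 2,5-dimethylphenyl, with a 3.5-fold lower number from compound 2 to compound 4 (0.54 log units; beyond the scatter). Nothing available gives a reason for these differences.

The compounds shown leave open whether an amine, a carboxylic acid or a longer chain on the amide-type nitrogen, in place of the substituted phenyl groups, would give a number outside the present range. Every step shown also sits on this one nitrogen while the shared core stays the same, so the effect of a change elsewhere remains open.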